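The source may hold more compounds than are shown below. What is called first, only, known or untested is meant among the compounds shown, and "the series" means these compounds.

Compound 1 `CC(/C=N/Nc1ccc([N+](=O)[O-])cc1)=N\NC(=O)c1ccccc1Cl` in a functional assay on cells (Splenocyte, Mus musculus, strain BALB/c) for inhibition, read by scintillation counting and thymidine incorporation, with a stated time of 72 h (a higher number here means a weaker inhibitor, a lower number a stronger inhibitor), gives > 12000 nM, which is a limit of the assay rather than a number.
Compound 2 `CC(/C=N/Nc1ccc([N+](=O)[O-])cc1)=N\NC(=O)c1ccc(N)cc1` in this assay gives > 12000 nM, again only a limit.
Compound 3 `CC(/C=N/Nc1ccc([N+](=O)[O-])cc1)=N\NC(=O)c1ccc(C(F)(F)F)cc1` in this assay gives > 12000 nM, likewise a limit.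

The three compounds share one core and differ only in the group carried on the carbonyl-bearing aromatic ring. Compound 3 therefore stands with no number of its own, at the limit of > 12000 nM in this assay, at which 3 of the 3 values shown sit. The two measured steps, a step that the two limits leave unreadable from compound 1 to compound 2 and a step that the two limits leave unreadable from compound 2 to compound 3, each join two limits and so reveal nothing about their size. Compound 4 `CC(/C=N/Nc1ccc([N+](=O)[O-])cc1)=N\NC(=O)c1ccc([N+](=O)[O-])cc1` alters compound 3 by nitro in place of trifluoromethyl on an aromatic carbon. For the measured compounds named here, no measured step shows how large such a change is here, and every earlier change on the same ring left the compound at the limit. The step expected in this assay is therefore a step that the limit leaves unreadable from compound 3 to compound 4, meaning no readable change, with a high chance that only a limit is reported again. Compound 4 is thus estimated at 20000 nM in this assay, with a range from 8000 nM to 60000 nM.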

Compound 4, half-maximal inhibitory concentration: 980 nM
For compound 4 the middle estimate is 20-fold (1.31 log units) above the measured one, outside the stated range (below it).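

In this assay, the group on this ring can decide whether a measurable inhibition appears at all: nitro gives an at least 12-fold lower number from compound 3 to compound 4 (1.08 log units; beyond the scatter) when it replaces trifluoromethyl, and an at least 12-fold lower number from compound 2 to compound 4 (1.08 log units; beyond the scatter) when it replaces amino. Replacing the whole 2-chlorophenyl with 4-nitrophenyl likewise gives an at least 12-fold lower number from compound 1 to compound 4 (1.08 log units; beyond the scatter). The earlier compounds gave no sign that this position mattered, and among the compounds shown, only nitro brings a value off the limit, which is a boundary of the assay rather than a number: the limit of > 12000 nM in this assay, at which 3 of the 4 values shown sit.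

On these data alone, the steps among compounds 1, 2 and 3 cannot be read, so how these three compare remains unknown, and each step to compound 4 gives only a minimum size. As far as these compounds go, whether a nitrile or a carboxylic acid on the same carbon would also give a value below the limit remains open.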